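The source may report more compounds than this note shows. Statements on the series, on what has been measured and on what is new or still open speak of the compounds shown alone.

Measured compounds in an in vitro assay on 293-EBNA cells for binding affinity to corticotropin-releasing factor receptor 1 (Homo sapiens); on this read-out higher numbers stand for weaker inhibition and lower numbers for stronger inhibition:

compound 1 `CCC(CC)Nc1nc(C)nc2c1nnn2-c1c(C)cc(C)cc1C` gives 5.7 nM
compound 2 `CCCCC(CC)Nc1nc(C)nc2c1nnn2-c1c(C)cc(C)cc1C` gives 7.6 nM
compound 3 `CCCC(C)Nc1nc(C)nc2c1nnn2-c1c(C)cc(C)cc1C` gives 7.1 nM

All three share one core and differ only in the branched alkyl group on the ring nitrogen. Compound 1 and compound 2 are related by ethyl in place of hydrogen on a saturated chain carbon, three bonds along the chain from a nitrogen on an aromatic ring, and that change gave a 1.3-fold higher number from compound 1 to compound 2 (0.12 log units; within the scatter). Compound 1 and compound 3 are related by 1-methylbutyl in place of pentan-3-yl on a nitrogen on an aromatic ring, a rearrangement of the same atoms, with a 1.2-fold higher number from compound 1 to compound 3 (0.10 log units; within the scatter). Compound 2 and compound 3 lie close together as well: a 1.1-fold lower number from compound 2 to compound 3 (0.03 log units; within the scatter). Nothing among the three changes the read-out in this assay beyond the usual scatter.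

Compound 4 `CCCC(CCC)Nc1nc(C)nc2c1nnn2-c1c(C)cc(C)cc1C` is not yet measured. It derives from compound 3 by ethyl in place of hydrogen on a saturated chain carbon, two bonds along the chain from a nitrogen on an aromatic ring. Within the data shown here, this is the same kind of change as the one from compound 1 to compound 2, but not the same: there the ethyl entered on a saturated chain carbon three bonds along the chain from a nitrogen on an aromatic ring, here it enters on a saturated chain carbon two bonds along the chain from a nitrogen on an aromatic ring. The two cores, compound 1 and compound 3, differ by 1-methylbutyl in place of pentan-3-yl on a nitrogen on an aromatic ring.

Because the earlier ethyl addition gave a 1.3-fold higher number from compound 1 to compound 2 (0.12 log units; within the scatter), the expected step from compound 3 to compound 4 in this assay is small, a 1.2-fold higher number from compound 3 to compound 4 (0.08 log units; within the scatter), resting on that single precedent and on the narrow spread of compound 1, compound 2 and compound 3. Compound 4 is therefore estimated at 8.5 nM, with a range from 4 nM to 18 nM.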

Compound 4, inhibition constant: 4 nM
Estimate against measurement, compound 4: 2.1-fold (0.33 log units) above, and the stated range covers the measured number.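

In this assay, ethyl in place of hydrogen on a saturated chain carbon, two bonds along the chain from a nitrogen on an aromatic ring, gives a 1.8-fold lower number from compound 3 to compound 4 (0.25 log units; within the scatter), and set beside the earlier ethyl addition on the other core it reads: the same change on two cores in this assay, a 1.3-fold higher number (0.12 log units; within the scatter) from compound 1 to compound 2 and a 1.8-fold lower number (0.25 log units; within the scatter) from compound 3 to compound 4, 2.4-fold (0.37 log units) apart, within the scatter of two such steps

The remaining new steps also stay within the scatter, with a 1.9-fold lower number from compound 2 to compound 4 (0.28 log units; within the scatter) and a 1.4-fold lower number from compound 1 to compound 4 (0.15 log units; within the scatter). The ethyl addition is therefore tolerated on both cores in this assay, with no measurable difference between them, but two small steps with opposite signs show neither a real effect that carries over nor a true reversal, and they do not separate the influence of the core from that of the place of attachment.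

All four compounds carry an open-chain branched alkyl group on the nitrogen and leave the rest of the shared core unchanged. Still open, on these data alone, is whether the same flat response holds for a longer chain such as 1-butylpentyl, a ring such as cyclopentyl, or a chain bearing a methoxy or hydroxyl group, and whether an ethyl addition behaves alike once the methyl group on the shared core is replaced by another group.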